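Fluoro in place of methyl, compound 3 to compound 4

A few compounds are considered here, and "the series" means these few. Any claim that something is new, unique, unknown or untested is made for them only; others in the source may bear on it.

Of the compounds shown here, three sharing one core have been read so far in a functional assay on cells (Erythrocyte, Rattus norvegicus) for inhibition, read by hemolysis, with a stated time of 1 h; a higher number here means a weaker inhibitor, a lower number a stronger inhibitor. Compound 1 `COc1cc(OC)c(OC)cc1/C=C/C(=O)c1ccc(Cl)cc1` gives 2.3 ug/mL, compound 2 `COc1cc(OC)c(OC)cc1/C=C/C(=O)c1ccccc1` gives 2.23 ug/mL, and compound 3 `COc1cc(OC)c(OC)cc1/C=C/C(=O)c1ccc(C)cc1` gives 2.24 ug/mL. Compound 3 cannot be separated from either of the other two on these numbers, since its gaps to both lie within the scatter.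

The next structure is compound 4 `COc1cc(OC)c(OC)cc1/C=C/C(=O)c1ccc(F)cc1`, reached through (fluoro in place of methyl on an aromatic carbon). This is fluoro in place of methyl on an aromatic carbon, para to a large group.

For the measured compounds named here, no fluoro compound has been measured yet, so the three steps among hydrogen, chloro and methyl at this place are the only guide. They are a 1.0-fold lower number from compound 1 to compound 2 (0.01 log units; within the scatter), a 1.0-fold lower number from compound 1 to compound 3 (0.01 log units; within the scatter) and a 1.0-fold higher number from compound 2 to compound 3 (0.00 log units; within the scatter), and all three stay within the scatter. On that basis, no step beyond the scatter is expected in this assay, and no direction can be assigned. The expected step is a 1.0-fold higher number from compound 3 to compound 4 (0.00 log units; within the scatter).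

For compound 4 the estimated value is 2.25 ug/mL, with an expected range of 1.5 ug/mL to 3.4 ug/mL.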

Compound 4, half-maximal inhibitory concentration: 2.22 ug/mL
Compound 4: the middle estimate sits 1.0-fold (0.01 log units) above what was measured; the measured number falls inside the stated range.
By their numbers in this assay, from the lowest: compounds 4, 2, 3 and 1 (each within the scatter of the next).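

In this assay, fluoro joins hydrogen, chloro and methyl on the aromatic carbon para to a large group, and all of its new steps stay within the scatter: a 1.0-fold lower number from compound 3 to compound 4 (0.00 log units; within the scatter), a 1.0-fold lower number from compound 2 to compound 4 (0.00 log units; within the scatter) and a 1.0-fold lower number from compound 1 to compound 4 (0.02 log units; within the scatter). The swap from 4-methylphenyl to 4-fluorophenyl therefore adds a fourth substituent to a flat reading, so compounds 1, 2, 3 and 4 cannot be ranked at this position, and the lack of separation now extends to a second halogen alongside chloro. No available measurement bears on why the number stays unmoved across these four compounds.

Going by these compounds, whether this position tolerates any substituent remains open, since an amine, a carboxylic acid or a longer chain in the same place could still produce a step beyond the scatter. Also open, on these data alone, is whether changes elsewhere on the shared core would move the number, as all four compounds differ only at this one place.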